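The compounds below may be only part of what the source reports. "The series", "measured", "known", "first", "only" and "open" are said of these compounds alone.

Compound 1 `O=C(CCCCC(S)CCS)NO` gives 1.17%
Compound 2 `O=C(CCCCC1CCSS1)Nc1cccc(C(F)(F)F)c1` gives 4.39%
Compound 3 `O=C(CCCCC1CCSS1)Nc1ccc([N+](=O)[O-])c(C(F)(F)F)c1` gives 19.1%

In a functional assay on NCI-H460 cells (Homo sapiens) for inhibition, read by MTT assay, with a stated time of 24 h, tested at 1 ug/mL (a lower number here means less inhibition of growth, a higher number more inhibition of growth at the concentration tested), compound 2 stands at 4.39%, within the scatter of compound 1 and beyond the scatter under compound 3. Compound 4 `O=C(CCCCC(S)CCS)Nc1cccc(C(F)(F)F)c1` differs from compound 2 as follows: a group of 5 heavy atoms (3 carbon, 2 sulfur; no ring) in place of a group of 5 heavy atoms (3 carbon, 2 sulfur; one five-membered non-aromatic ring with 2 hetero atoms), on a saturated chain carbon, four bonds along the chain from a carbonyl carbon. For the measured compounds named here, the only measured step, a number 14.7 percentage points higher from compound 2 to compound 3 (beyond the scatter), is a different change, nitro in place of hydrogen on an aromatic carbon, so it offers little guidance here. Compound 1 also carries the 1,3-disulfanylpropyl group but has no aromatic ring, and it gives 1.17%. No step beyond the scatter is therefore expected. The estimated step is a number 1.6 percentage points higher from compound 2 to compound 4 (within the scatter). For compound 4 the expected value is 6%, with an estimated range from 0% to 20%.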

Compound 4, percent growth inhibition at one concentration: 8.26%
Compound 4: the middle estimate sits 2.3 percentage points below what was measured; the measured number falls inside the stated range.
By their numbers in this assay, from the lowest: compounds 1, 2 and 4 (each within the scatter of the next); then compound 3.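

In this assay, replacing the five-membered ring with the open 1,3-disulfanylpropyl group on this saturated chain carbon gives a number 3.9 percentage points higher from compound 2 to compound 4 (within the scatter). At this position, then, the ring and the open group cannot be told apart in this read-out, although only the entering group carries hydrogen-bond donors. Nothing available explains this result. Going by these compounds, it remains open whether the same ring opening would give a step beyond the scatter on compound 3, which carries the nitro group. Also open, on these data alone, is how a carboxylic acid in place of the sulfur-bearing group would read.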